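The source may report more compounds than this note shows. Statements on the series, on what has been measured and on what is new or still open speak of the compounds shown alone.

Measured so far in an assay on a protein complex for inhibition of CDK8/Cyclin C (Homo sapiens), with a stated time of 1 h, tested at 10 uM; on this read-out higher numbers stand for more inhibition at the one concentration tested (going by the name of the read-out) and lower numbers for less inhibition:

compound 1 `O=C(O)[C@@H]1CCCN1C(=O)/C=C/c1ccncc1-c1ccc2ccccc2c1` gives 67%
compound 2 `NNC(=O)CCc1ccncc1-c1ccc2ccccc2c1` gives 102%
compound 3 `Cn1ncc2cc(-c3cnccc3/C=C/C(=O)O)ccc21` gives 102%

Compound 2 and compound 3 stand level at the digits recorded; together they hold the highest numbers of the three. Compound 1 is the furthest from compound 2, its value lying beyond the scatter below. Going by the values given here, no step between measured compounds differs in a single place, so no single change has been sized.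

The next compound, compound 4 `CNC(=O)CCc1ccncc1-c1ccc2ccccc2c1`, differs from compound 2 by methyl in place of amino on an amide-type nitrogen. With nothing shown for this change, the step of a number 10 percentage points lower from compound 2 to compound 4 (within the scatter) in this assay is expected to be small, downward if anything, and not beyond the scatter. Compound 4 is estimated at 92%, within 65% to 105%.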

Compound 4, a percentage reported as inhibition, at one concentration (the size of the read-out at that concentration, not a potency): 100%
For compound 4 the middle estimate is 8 percentage points below the measured one; the range from low to high includes it.
By their numbers in this assay, from the lowest: compound 1; then compounds 4, 2 and 3 (each within the scatter of the next).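

In this assay, a number 2 percentage points lower from compound 2 to compound 4 (within the scatter) gives the series its first step in a single place. At this one concentration, amino on the amide-type nitrogen can give way to methyl with a step that stays within the scatter, even though the hydrogen-bond donor and acceptor counted on amino leave with it. Nothing here gives a reason for this result.

Still open, from the compounds shown here alone, is whether a longer chain such as propyl, or a phenyl ring, on this nitrogen would hold the read-out, and likewise a carboxylic acid in place of the amide. Potency for compound 2 and compound 4 also remains open, as the read-out covers one concentration only.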